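The compounds below may be only part of what the source reports. "The series", "measured", "known", "first", "only" and "open" are said of these compounds alone.

Measured so far in an assay on isolated protein for inhibition of endoplasmic reticulum mannosyl-oligosaccharide 1,2-alpha-mannosidase (Homo sapiens); a lower number here means a stronger inhibitor, a higher number a weaker inhibitor:
Compound 1 `C[C@H](O)NC[C@H]1NC[C@H](O)[C@@H]1O` gives 488000 nM.
Compound 2 `OC[C@H](NC[C@H]1N[C@H](CO)[C@H](O)[C@@H]1O)c1ccccc1` gives 24600 nM.
Compound 3 `O[C@H]1[C@@H](O)CN[C@@H]1CN[C@@H](COCOc1cccc(Br)c1)c1ccccc1` gives 310 nM.

Compound 1 stands at the highest number of the three; compound 2 lies well below it and compound 3 furthest below, both gaps beyond the scatter. Compound 4 `NC[C@H]1NC[C@H](O)[C@@H]1O` is not yet measured. It differs from compound 1 in one place: hydrogen in place of 1-hydroxyethyl on an amine nitrogen. Among the measured compounds shown here, no measured pair shows this change on its own, so there is no step to read it from; compound 2 and compound 3 each differ from compound 1 in several places at once. With the 1-hydroxyethyl removed, no gain is expected in this assay; a step toward a higher number, or none beyond the scatter, seems most likely. The estimate for compound 4 is 650000 nM, within 150000 nM to 2500000 nM. The step from compound 1 to compound 4 is thus expected to be a 1.3-fold higher number from compound 1 to compound 4 (0.12 log units; within the scatter).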

Compound 4, inhibition constant: 1590 nM
Compound 4: middle estimate off by 410-fold (2.61 log units), on the high side; the measured number lies below the stated range.
By their numbers in this assay, from the lowest: compound 3; then compound 4; then compound 2; then compound 1.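

In this assay, among the compounds shown here, hydrogen in place of 1-hydroxyethyl on an amine nitrogen gives a 310-fold lower number from compound 1 to compound 4 (2.49 log units; beyond the scatter) and is the first step that isolates a single change. This position is therefore highly sensitive to its substituent, and within this pair the 1-hydroxyethyl is strongly disfavoured relative to hydrogen. Nothing available explains the size of this step.

Still open, as far as these compounds go, is whether the hydroxyl or the carbon chain accounts for the step. A methyl or an ethyl on the same nitrogen would help separate the two.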